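The compounds below may be only part of what the source reports. "The series", "measured", "known", "first", "only" and "open" are said of these compounds alone.

Measured compounds:
compound 1 `CN(C)CC[C@H](CSc1ccccc1)Nc1ccc(S(=O)(=O)NC(=O)c2ccc(N3CCN(Cc4ccccc4-c4ccc(Cl)cc4)CC3)cc2)cc1OC(F)(F)F`: < 1 nM
compound 2 `CN(C)CC[C@H](CSc1ccccc1)Nc1ccc(S(=O)(=O)NC(=O)c2ccc(N3CCN(CC4=C(c5ccc(Cl)cc5)CCC(C)(C)C4)CC3)cc2)cc1[N+](=O)[O-]`: < 1 nM

In an assay on isolated protein for displacement of a labelled ligand from Apoptosis regulator Bcl-2 (Homo sapiens), read by fluorescence polarization (a lower number here means a stronger inhibitor, a higher number a weaker inhibitor), compound 1 gives < 1 nM, which is a limit of the assay rather than a number. Compound 2 in this assay likewise gives < 1 nM, again a limit. Both values sit at the limit of < 1 nM in this assay, at which 2 of the 2 values shown sit, so no ordering between them can be read.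

Compound 3 `Cc1cc(S(=O)(=O)NC(=O)c2ccc(N3CCN(Cc4ccccc4-c4ccc(Cl)cc4)CC3)cc2)ccc1N[C@H](CCN(C)C)CSc1ccccc1` differs from compound 1 by methyl in place of trifluoromethoxy on an aromatic carbon. For the measured compounds named here, no measured pair shows this kind of change, so the expected step is uncertain; compound 3 is estimated to stay near the limit, with a step of an at least 1.5-fold higher number from compound 1 to compound 3 (0.17 log units; that floor lies within the scatter) expected. Compound 3 is estimated at 1.5 nM, ranging from 0.3 nM to 10 nM.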

Compound 3, inhibition constant: < 1 nM
Compound 3 ended at the assay's limit; the forecaster's own chance of this, stated with the estimate: 40%; middle value at least 1.5-fold (0.17 log units) from the limit.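

In this assay, for the compounds shown here, compound 3 gives < 1 nM as a limit of the assay, and no step from compound 1 to compound 3 can be read. As far as these compounds go, what methyl in place of trifluoromethoxy does to the value stays open.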